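The source may report more compounds than this note shows. Statements on the series, on what has been measured and on what is new or still open speak of the compounds shown alone.

For the measured compounds named here, in a functional assay on MM96L cells (Homo sapiens) for antiproliferative activity (on this read-out higher numbers stand for weaker inhibition and lower numbers for stronger inhibition), two compounds built on a shared core have numbers so far. Compound 1 `CN(C)c1ccc(C(=O)N[C@H](CCCCCC(=O)NO)C(=O)NCc2ccccc2)cc1` gives 160 nM and compound 2 `O=C(CCCCC[C@H](NC(=O)c1cc2ccccc2[nH]1)C(=O)NCc1ccccc1)NO` gives 250 nM. Compound 2 thus holds the higher of the two numbers, but its gap to compound 1 lies within the scatter, so the two cannot be ranked. Compound 3 `O=C(/C=C/c1c[nH]c2ccccc12)N[C@@H](CCCCCC(=O)NO)C(=O)NCc1ccccc1` departs from compound 2 with 2-(1H-indol-3-yl)ethenyl in place of 1H-indol-2-yl on a carbonyl carbon. Going by the values given here, no measured pair shows this change on its own, so the data offer only a weak guide. With compound 2 at 250 nM as the starting point, no step beyond the scatter is expected in this assay, and no direction is favoured. The estimated change is a 1.3-fold lower number from compound 2 to compound 3 (0.10 log units; within the scatter). For compound 3 the expected value is 200 nM, within an estimated range of 70 nM to 550 nM.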

Compound 3, half-maximal inhibitory concentration: 3240 nM
The estimate for compound 3 lay 16-fold (1.21 log units) below the measured number; the measured number lies above the stated range.
By their numbers in this assay, from the lowest: compounds 1 and 2 (each within the scatter of the next); then compound 3.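

In this assay, for the compounds shown here, the group on the carbonyl carbon proves far from freely exchangeable: replacing 1H-indol-2-yl with 2-(1H-indol-3-yl)ethenyl gives a 13-fold higher number from compound 2 to compound 3 (1.11 log units; beyond the scatter), the first step that can be read beyond the scatter. The two groups have the same ring types and the same hydrogen-bond donor and acceptor counts, so matching these features does not preserve the number. Nothing in the available data accounts for the size of this step.

The step combines a different indole attachment with an added ethenyl unit carrying a double bond outside the aromatic rings, and the compounds shown do not separate the two. On these data alone, it remains open how 1H-indol-3-yl placed directly on the carbonyl carbon, 2-(1H-indol-2-yl)ethenyl or the saturated 2-(1H-indol-3-yl)ethyl would compare with compound 2.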